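Thiophene exchange on the core of compound 3

The source may report more compounds than this note shows. Statements on the series, on what has been measured and on what is new or still open speak of the compounds shown alone.

In an ADME assay on PBMC cells (Homo sapiens) for cytotoxicity, with a stated time of 5 days (a higher number here means a weaker inhibitor, a lower number a stronger inhibitor), compound 1 `Cc1cc(C(=O)/C=C/c2ccc(N3CCCCC3)cc2)c(C)s1` gives 38200 nM. Compound 2 `O=C(/C=C/c1ccc(N2CCCCC2)cc1)c1ccc(I)s1` reaches only the assay limit > 100000 nM in this assay. The step of an at least 2.6-fold higher number from compound 1 to compound 2 (0.41 log units; beyond the scatter) rests on (the limit of > 100000 nM in this assay, at which 1 of the 3 values shown sits). Compound 3 `Cc1csc(C2=NNC(c3ccc(N4CCCCC4)cc3)C2)c1` gives 24400 nM in this assay, and compound 1 sits within the scatter of compound 3.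

Compound 4 `Brc1ccsc1C1=NNC(c2ccc(N3CCCCC3)cc2)C1` differs from compound 3 by 3-bromothiophen-2-yl in place of 4-methylthiophen-2-yl on a carbon with a double bond to nitrogen. Among the measured compounds shown here, the only measured step that exchanges a thiophene is an at least 2.6-fold higher number from compound 1 to compound 2 (0.41 log units; beyond the scatter), on the core of compound 1 rather than that of compound 3, and it is bounded by the limit of > 100000 nM in this assay, at which 1 of the 3 values shown sits. For compound 4 a step of a 1.4-fold higher number from compound 3 to compound 4 (0.16 log units; within the scatter) toward a higher number is expected, modest at most. Compound 4 is estimated at 35000 nM in this assay, between 12000 nM and 100000 nM.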

Compound 4, half-maximal inhibitory concentration: 57000 nM
Beside the measured number, compound 4's estimate is 1.6-fold (0.21 log units) below it; low and high end bracket the measured number.
By their numbers in this assay, from the lowest: compounds 3, 1 and 4 (each within the scatter of the next, the first and the last beyond it). At a limit, above all of these: compound 2.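

In this assay, the thiophene on the carbon with a double bond to nitrogen is a position where an exchange can be read on the core of compound 3: 3-bromothiophen-2-yl in place of 4-methylthiophen-2-yl gives a 2.3-fold higher number from compound 3 to compound 4 (0.37 log units; beyond the scatter). This is a measured step beyond the scatter with both ends as numbers, and it runs in the same direction as an at least 2.6-fold higher number from compound 1 to compound 2 (0.41 log units; beyond the scatter) on the core of compound 1. That earlier step ends at a limit for compound 2: the limit of > 100000 nM in this assay, at which 1 of the 4 values shown sits.

From the compounds shown here alone, whether the bromine or the missing methyl carries the step stays open. So does the effect of an unsubstituted thiophene, a phenyl ring or a methoxy group at this place.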